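Swapping the carbamoyl for trifluoromethyl on the shared core

The source may report more compounds than this note shows. Statements on the series, on what has been measured and on what is new or still open speak of the compounds shown alone.

Of the compounds shown here, two have been measured in an assay for inhibition of Fatty-acid amide hydrolase 1 (Rattus norvegicus); a lower number here means a stronger inhibitor, a higher number a weaker inhibitor. Compound 1, `NC(=O)c1cnc(C(=O)CCc2ccc(Oc3ccccc3)cc2)o1`, gives 6.6 nM in this assay. Compound 2, `COC(=O)c1cc(-c2cnc(C(=O)CCc3ccc(-c4ccccc4)cc3)o2)ccn1`, gives 1.5 nM in this assay. Among these two numbers compound 1 has the higher one, and the gap to compound 2 is beyond the usual scatter, so compound 1 is the weaker inhibitor of the pair.

Compound 3, `O=C(CCc1ccc(Oc2ccccc2)cc1)c1ncc(C(F)(F)F)o1`, has not been measured. It differs from compound 1 in one place: trifluoromethyl in place of carbamoyl on an aromatic carbon. The group leaves from an aromatic carbon of a five-membered aromatic ring with 1 nitrogen and 1 oxygen.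

For the measured compounds named here, no measured pair shows what this exchange does in this assay, so the expectation rests on compound 1 alone. The step of a 1.2-fold higher number from compound 1 to compound 3 (0.08 log units; within the scatter) is expected to stay close to the scatter, with no clear direction. Compound 3 is therefore estimated at 8 nM, within a range from 2 nM to 30 nM.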

Compound 3, inhibition constant: 2 nM
Beside the measured number, compound 3's estimate is 4.0-fold (0.60 log units) above it, within the range that was stated.
By their numbers in this assay, from the lowest: compounds 2 and 3 (each within the scatter of the next); then compound 1.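

In this assay, placing trifluoromethyl in place of carbamoyl on the aromatic carbon next to the ring oxygen gives a 3.3-fold lower number from compound 1 to compound 3 (0.52 log units; beyond the scatter). For the compounds shown here, this is the first comparison here that changes only this position, and it shows that the group held there can move the number beyond the scatter. It also shows that strong inhibition on this core does not depend on carbamoyl, as trifluoromethyl has no hydrogen-bond donor or acceptor, yet compound 3 gives the lower number; nothing available explains the change.

One exchange cannot separate what is lost with carbamoyl from what is gained with trifluoromethyl. The compounds shown also leave open how a carboxylic acid, a nitrile or a single chlorine atom at this position would compare in this assay.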